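Swapping fluoro for isopropoxy on a cytotoxic cyclopentenone

This account rests on a few compounds, and the source may have more. Where it says the series, first, only, none or still open, it means among the compounds named here.

Compound 1 `COc1ccc(C2=C(c3cc(OC)c(OC)c(OC)c3)C(=O)C(OC(C)=O)C2)cc1F`: < 1 ug/mL
Compound 2 `COc1ccc(C2=C(c3cc(OC)c(OC)c(OC)c3)C(=O)CC2O[SiH2]C(C)(C)C)cc1OC`: > 100 ug/mL
Compound 3 `COC(=O)c1cc(C2=C(c3cc(OC)c(OC)c(OC)c3)C(=O)CC2O[SiH2]C(C)(C)C)ccc1OC`: > 100 ug/mL

The read-out here is an ADME assay on L132 cells (Homo sapiens) for cytotoxicity, read by MTT assay, with a stated time of 72 h; on this read-out lower numbers stand for stronger inhibition and higher numbers for weaker inhibition. In this assay compound 1 gives < 1 ug/mL, which is a limit of the assay and not a number, so compound 1 stands at the limit of < 1 ug/mL in this assay, at which 1 of the 3 values shown sits. The other two values also sit at a limit: compound 2 gives > 100 ug/mL in this assay. Compound 3 likewise gives > 100 ug/mL. Going by the values given here, both therefore stand at the limit of > 100 ug/mL in this assay, at which 2 of the 3 values shown sit, and the only measured step, a step that the two limits leave unreadable from compound 2 to compound 3, cannot be read for size, so it gives no guide to how a change on the aromatic ring shifts this assay.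

Compound 4 `COc1ccc(C2=C(c3cc(OC)c(OC)c(OC)c3)C(=O)C(OC(C)=O)C2)cc1OC(C)C` is compound 1 with a single change: isopropoxy in place of fluoro on an aromatic carbon. Among the compounds with values here, no measured step bears on this change, since compounds 2 and 3 differ from compound 1 in more than one place. Within the data shown here, their values show only that the silyl-ether compounds sit at the upper limit while the acetate compound 1 sits at the lower one.

With the acetate kept, compound 4 is expected to stay strongly cytotoxic, estimated at 1.5 ug/mL with a range from 0.3 ug/mL to 8 ug/mL. The expected step is an at least 1.5-fold higher number from compound 1 to compound 4 (0.17 log units; that floor lies within the scatter), which may well remain within scatter.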

Compound 4, half-maximal inhibitory concentration: > 100 ug/mL
Compound 4: a limit, no number (the forecaster's own chance of this, stated with the estimate: 35%); at least 66-fold (1.82 log units) between middle value and limit.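

Isopropoxy in place of fluoro, ortho to a methoxy group, gives an at least 100-fold higher number from compound 1 to compound 4 (2.00 log units; beyond the scatter), so a change at this one aromatic carbon is enough to move the compound from one end of the reported values to the other. In this assay compound 4 gives > 100 ug/mL, which is a limit of the assay and not a number. Compound 1 and compound 4 both carry the acetate, so the acetate alone does not secure strong cytotoxicity, and the group on this aromatic carbon matters as well: the limit of > 100 ug/mL in this assay, at which 3 of the 4 values shown sit.

With the acetate kept, only fluoro and isopropoxy are seen at this carbon, so the values show neither where between these two groups the cytotoxicity is lost nor why it is lost. Compounds carrying a hydroxyl group, an ethoxy group or an amine at this carbon, with the rest of compound 1 unchanged, would show whether only fluoro gives a low value here or whether other groups do too.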